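A Second Look at a Nitrophenyl Sulfonyl Swap

The source may hold more compounds than are shown below. What is called first, only, known or untested is meant among the compounds shown, and "the series" means these compounds.

Compound 1 `N#C/C(=C\c1ccccc1OS(=O)(=O)c1ccc([N+](=O)[O-])cc1)C(=O)Nc1nnc(Cc2ccc(F)cc2)s1` — 8%
Compound 2 `N#C/C(=C\c1ccccc1OS(=O)(=O)c1ccccc1[N+](=O)[O-])C(=O)Nc1nnc(Cc2ccc(F)cc2)s1` — 6%
Compound 3 `N#C/C(=C\c1ccccc1OS(=O)(=O)c1ccc([N+](=O)[O-])cc1)C(=O)Nc1nnc(Cc2ccc(Cl)cc2)s1` — 19%

Three compounds were measured in an ADME assay on HEK-293T cells (Homo sapiens) for inhibition, read by CCK-8 assay, with a stated time of 48 h, tested at 20 uM; on this read-out lower numbers stand for less inhibition of growth and higher numbers for more inhibition of growth at the one concentration tested. Compound 1 and compound 2 differ by 2-nitrophenyl in place of 4-nitrophenyl on a sulfonyl sulfur, and the step was a number 2 percentage points lower from compound 1 to compound 2 (within the scatter). Compound 3 carries a different core, differing from compound 1 by chloro in place of fluoro on an aromatic carbon, with the step of a number 11 percentage points higher from compound 1 to compound 3 (beyond the scatter); in this assay compound 3 gives 19%, the highest of the three. Compound 4 `N#C/C(=C\c1ccccc1OS(=O)(=O)c1ccccc1[N+](=O)[O-])C(=O)Nc1nnc(Cc2ccc(Cl)cc2)s1` is not yet measured; it differs from compound 3 by 2-nitrophenyl in place of 4-nitrophenyl on a sulfonyl sulfur, the same change that turned compound 1 into compound 2. Because that earlier step was a number 2 percentage points lower from compound 1 to compound 2 (within the scatter), within the scatter, the step from compound 3 to compound 4 is expected to be small as well, a number 2 percentage points lower from compound 3 to compound 4 (within the scatter). Compound 4 is therefore estimated at 17%, expected to fall between 5% and 29%.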

Compound 4, percent growth inhibition at one concentration: 20%
Compound 4: the middle estimate sits 3 percentage points below what was measured; measured number inside the range.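

In this assay, 2-nitrophenyl in place of 4-nitrophenyl on the sulfonyl sulfur gave a number 1 percentage points higher from compound 3 to compound 4 (within the scatter), and the change read alike on both cores: the same change on two cores in this assay, a number 2 percentage points lower (within the scatter) from compound 1 to compound 2 and a number 1 percentage points higher (within the scatter) from compound 3 to compound 4, 3 percentage points apart, within the scatter of two such steps. Chloro in place of fluoro gave a number 14 percentage points higher from compound 2 to compound 4 (beyond the scatter), and this change also read alike whichever nitrophenyl group was present: the same change on two cores in this assay, a number 11 percentage points higher (beyond the scatter) from compound 1 to compound 3 and a number 14 percentage points higher (beyond the scatter) from compound 2 to compound 4, 3 percentage points apart, within the scatter of two such steps. This shows that both changes carried across these four compounds at the one concentration tested, but it does not show that either would carry to any other core in the series.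

The compounds shown leave open what an amine or a carboxylic acid in place of the nitro group would do. They also leave open how bromo in place of chloro would read.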